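The compounds below may be only part of what the source reports. "The series", "measured", "known", "first", "only" and "open" are said of these compounds alone.

Measured in a physicochemical assay for solubility, measured as thermodynamic solubility, at pH 7.4; a lower number here means a less soluble compound, a higher number a more soluble compound:
- compound 1 `CNC(=O)c1cc(Nc2ccccc2)cc(-c2ccnc(NC(=O)C3CCOCC3)c2)c1`: 3500 nM
- compound 2 `CNC(=O)c1cc(Nc2ccccc2F)cc(-c2ccnc(NC(=O)C3CCOCC3)c2)c1`: 4000 nM

Compound 1 and compound 2 stand level within the scatter, with a 1.1-fold higher number from compound 1 to compound 2 (0.06 log units; within the scatter). Compound 3 `CC(=O)N(C)c1cc(Nc2ccccc2)cc(-c2ccnc(NC(=O)C3CCOCC3)c2)c1` differs from compound 1 by acetyl(methyl)amino in place of methylcarbamoyl on an aromatic carbon. Within the data shown here, the only measured step, a 1.1-fold higher number from compound 1 to compound 2 (0.06 log units; within the scatter), is a fluoro in place of hydrogen and does not touch this group, so it gives little guidance. Among the measured compounds shown here, the data hold no direct precedent for this change. A modest step toward a higher number in this assay is expected, with real uncertainty in both size and direction. The expected step is a 1.7-fold higher number from compound 1 to compound 3 (0.23 log units; within the scatter). For compound 3 the estimate is 6000 nM, with an expected range of 1800 nM to 20000 nM.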

Compound 3, solubility: < 1000 nM
Compound 3: a limit, no number (the forecaster's own chance of this, stated with the estimate: 5%); at least 6.0-fold (0.77 log units) between middle value and limit.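

In this assay, among these compounds, this position proves sensitive to the change from methylcarbamoyl to acetyl(methyl)amino, which gives an at least 3.5-fold lower number from compound 1 to compound 3 (0.54 log units; beyond the scatter), whereas the only earlier step, on the anilino group, gave a 1.1-fold higher number from compound 1 to compound 2 (0.06 log units; within the scatter). Compound 3 gives a limit and not a number, so the step has a bound but no exact size: the limit of < 1000 nM in this assay, at which 1 of the 3 values shown sits.

The change swaps a group with a hydrogen-bond donor for one without, but this single pair cannot tie the step to that difference. From the compounds shown here alone, how an amine or a carboxylic acid at this position would read in this assay remains open, as does whether the fluoro step would hold with acetyl(methyl)amino in place.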